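Trimming the Alkyne Substituent to Cyclopropyl

The source may report more compounds than this note shows. Statements on the series, on what has been measured and on what is new or still open speak of the compounds shown alone.

Compound 1 `CC(C)=C(C)C#Cc1ccc(CCC(=O)O)cc1` stands at the top of the two numbers shown in a functional assay on 1321-N1 cells for agonist activity at Free fatty acid receptor 1 (Homo sapiens), read by calcium flux, with a stated time of 0.4 s; on this read-out lower numbers stand for smaller maximal responses and higher numbers for larger maximal responses: compound 1 gives 105%, and compound 2 `C/C=C(\C)C#Cc1ccc(CCC(=O)O)c(F)c1`, within the scatter of it, gives 97%. Compound 3 `O=C(O)CCc1ccc(C#CC2CC2)cc1` has not yet been measured in this assay. It differs from compound 1 by cyclopropyl in place of 1,2-dimethylprop-1-en-1-yl on a triple-bonded carbon. For the measured compounds named here, no step between measured compounds is available to gauge this change, so only a modest decrease, around the edge of the scatter, is expected; the estimated step is a number 15 percentage points lower from compound 1 to compound 3 (beyond the scatter). Compound 3 is expected to reach 90%, with a range from 60% to 115%.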

Compound 3, largest response reached (reported as efficacy), in percent of the reference or control that the assay uses: 128%
Compound 3: middle estimate off by 38 percentage points, on the low side; the measured number lies above the stated range.
By their numbers in this assay, from the lowest: compounds 2 and 1 (each within the scatter of the next); then compound 3.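

In this assay, the step to cyclopropyl on the triple-bonded carbon is upward, a number 23 percentage points higher from compound 1 to compound 3 (beyond the scatter). For the compounds shown here, this is the first change read at this place, and it shows that the maximal response survives the loss of the double bond outside aromatic rings and of the open 1,2-dimethylprop-1-en-1-yl group, and even rises beyond the scatter with a smaller group carrying a ring. Nothing available explains this rise. The compounds shown leave open whether cyclobutyl or tert-butyl on the same triple-bonded carbon would keep this response, and so whether the ring or the smaller size goes with it.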